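Acetamido replacing trifluoromethyl in an alkynyl thiazole series

A few compounds are considered here, and "the series" means these few. Any claim that something is new, unique, unknown or untested is made for them only; others in the source may bear on it.

In a functional assay on CHO cells for agonist activity at metabotropic glutamate receptor 5 (Homo sapiens), read by inositol phosphate accumulation (on this read-out lower numbers stand for stronger inhibition and higher numbers for weaker inhibition), compound 3 `Cc1nc(C#Cc2cccc(C(F)(F)F)c2)cs1` gives 413 nM, the highest of the three numbers measured. Compound 1 `Cc1nc(C#Cc2cccc(F)c2)cs1` gives 23 nM and compound 2 `COc1ccccc1C#Cc1csc(C)n1` gives 36.3 nM in this assay. Compound 4 `CC(=O)Nc1cccc(C#Cc2csc(C)n2)c1` carries acetamido in place of trifluoromethyl on an aromatic carbon. Among the measured compounds shown here, the only measured step at that position is an 18-fold higher number from compound 1 to compound 3 (1.25 log units; beyond the scatter), which shows that a bulkier group on that aromatic carbon raised the number markedly. Acetamido is of similar size to trifluoromethyl, so the step to compound 4 is expected to be small or at most modest, likely upward, as a 1.7-fold higher number from compound 3 to compound 4 (0.23 log units; within the scatter). Compound 4 is therefore estimated at 700 nM in this assay, with a range from 150 nM to 3500 nM.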

Compound 4, half-maximal inhibitory concentration: 2020 nM
The estimate for compound 4 lay 2.9-fold (0.46 log units) below the measured number; the range from low to high includes it.
By their numbers in this assay, from the lowest: compounds 1 and 2 (each within the scatter of the next); then compound 3; then compound 4.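

In this assay acetamido and trifluoromethyl have the same count of heavy atoms, yet the swap gives a 4.9-fold higher number from compound 3 to compound 4 (0.69 log units; beyond the scatter), so that count alone does not set the number at this aromatic carbon. Measured against fluoro, acetamido gives an 88-fold higher number from compound 1 to compound 4 (1.94 log units; beyond the scatter), and of the three groups at this position fluoro keeps the lowest number. Nothing available here explains the difference between these groups.

On these data alone, whether the amide hydrogen or the carbonyl of acetamido matters more remains open. As far as these compounds go, how a free amine or a chloro group would read on this carbon is also open.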